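Trimming an Allyl Ether to Ethyl on a Shared Core

A few compounds are considered here, and "the series" means these few. Any claim that something is new, unique, unknown or untested is made for them only; others in the source may bear on it.

Compound 1 `CCCCCCOc1ccc2c(Cl)ccnc2c1` in a functional assay on SK-OV-3 cells (Homo sapiens) for cytotoxicity, read by MTT assay, with a stated time of 48 h (a lower number here means a stronger inhibitor, a higher number a weaker inhibitor), gives only the assay limit, > 10000 nM, so no number is known for it. Going by the values given here, compound 2 `C=CCOc1ccc2c(NCCN(C)C)ccnc2c1`, which carries the dimethylaminoethylamino group on the shared core, gives 1560 nM in this assay, the only real number in the set. Compound 3 `CCOc1ccc2c(NCCN(C)C)ccnc2c1` differs from it by methyl in place of vinyl on a saturated chain carbon bound to an oxygen on an aromatic ring. Among the compounds with values here, no measured pair shows what such a change does here, so the step of a 1.0-fold lower number from compound 2 to compound 3 (0.02 log units; within the scatter) is expected to stay within the usual scatter. Compound 3 is therefore estimated at 1500 nM, between 600 nM and 4000 nM.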

Compound 3, half-maximal inhibitory concentration: 4620 nM
Beside the measured number, compound 3's estimate is 3.1-fold (0.49 log units) below it, outside the stated range (above it).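

Going by these compounds alone, the change from allyloxy to ethoxy gives a 3.0-fold higher number from compound 2 to compound 3 (0.47 log units; beyond the scatter) in this assay, the first measured step at this place. On this core and with this dimethylaminoethylamino group, this small change to the ether is therefore enough to move the number beyond the scatter, and compound 2 is the stronger of the pair. Nothing shown gives a cause for this step.

The pair leaves open whether the loss of the double bond or the shorter chain accounts for the step. A propyl ether, which has the length of the allyl chain without its double bond, could separate the two.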